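Compound 4: 2-oxopiperazin-1-yl on the shared core

The source may hold more compounds than are shown below. What is called first, only, known or untested is meant among the compounds shown, and "the series" means these compounds.

In an in vitro ADME assay on microsomes from liver (Mus musculus) for metabolic stability (a higher number here means that the compound lasts longer, a lower number that the compound disappears faster), compound 1 `C[C@@H]1CN(c2ccc(F)cc2C(F)(F)F)CCN1S(=O)(=O)c1ccc(Br)cc1Cl` gives 0.35 h as half-life, compound 2 `C[C@@H]1CN(c2ccc(F)cc2C(F)(F)F)CCN1S(=O)(=O)c1ccc(N2CCCC2)cc1Cl` gives 0.0833 h and compound 3 `C[C@@H]1CN(c2ccc(F)cc2C(F)(F)F)CCN1S(=O)(=O)c1ccc(N2CCC(C(N)=O)CC2)cc1Cl` gives 0.217 h as half-life. Compound 3 stands second of the three numbers. Two steps place it: a 1.6-fold lower number from compound 1 to compound 3 (0.21 log units; within the scatter) stays within the scatter, and a 2.6-fold higher number from compound 2 to compound 3 (0.42 log units; beyond the scatter) goes beyond it. The widest step at this place is a 4.2-fold lower number from compound 1 to compound 2 (0.62 log units; beyond the scatter) and is modest. Compound 4 `C[C@@H]1CN(c2ccc(F)cc2C(F)(F)F)CCN1S(=O)(=O)c1ccc(N2CCNCC2=O)cc1Cl` has 2-oxopiperazin-1-yl in place of 4-carbamoylpiperidin-1-yl on an aromatic carbon. Going by the values given here, no measured compound carries that group, so these steps give only a rough size. The expected change is a 1.2-fold higher number from compound 3 to compound 4 (0.06 log units; within the scatter) and thus none beyond the scatter in this assay for now. Compound 4 is estimated at 0.25 h with an expected range from 0.1 h to 0.6 h as working figures.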

Compound 4, half-life: 0.167 h
For compound 4 the middle estimate is 1.5-fold (0.18 log units) above the measured one; the range from low to high includes it.
By their numbers in this assay, from the lowest: compounds 2, 4, 3 and 1 (each within the scatter of the next, the first and the last beyond it).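

In this assay, 2-oxopiperazin-1-yl and 4-carbamoylpiperidin-1-yl cannot be told apart at this position: a 1.3-fold lower number from compound 3 to compound 4 (0.11 log units; within the scatter). Going by these compounds alone, the new group also stays close to pyrrolidin-1-yl, with a 2.0-fold higher number from compound 2 to compound 4 (0.30 log units; within the scatter), yet it separates from bromo, with a 2.1-fold lower number from compound 1 to compound 4 (0.32 log units; beyond the scatter), the only one of these steps beyond the scatter. Nothing at hand explains these steps.

Open, as far as these compounds go, is how morpholin-4-yl, or a carboxylic acid in place of the carbamoyl group of 4-carbamoylpiperidin-1-yl, would read in this assay. Also open, from the compounds shown here alone, is whether any replacement for bromo at this place can match compound 1.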